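From 3-fluorophenyl to 4-(tert-butyl)phenyl on a sulfur

A few compounds are considered here, and "the series" means these few. Any claim that something is new, unique, unknown or untested is made for them only; others in the source may bear on it.

Compound 1 `Nc1ccccc1NC(=O)/C=C/c1ccc(CSc2cccc(F)c2)cc1` gives 8.56%
Compound 2 `Nc1ccccc1NC(=O)c1ccc(CSc2cccc(F)c2)cc1` gives 18.6%
Compound 3 `Nc1ccccc1NC(=O)c1ccc(CSc2nccc(C(F)(F)F)n2)cc1` gives 66.1%

These three compounds were tested in a functional assay on SMMC-7721 cells (Homo sapiens) for inhibition, read by CCK-8 assay, with a stated time of 72 h, tested at 2 uM (a higher number here means more inhibition of growth at the concentration tested, a lower number less inhibition of growth), and the numbers fall into two groups. Compound 1 (8.56%) lies within the usual scatter of compound 2 (18.6%). Compound 3 (66.1%) stands beyond the scatter from compound 1, at a clearly higher number.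

Compound 4 `CC(C)(C)c1ccc(SCc2ccc(/C=C/C(=O)Nc3ccccc3N)cc2)cc1` has not yet been measured. It differs from compound 1 by a single exchange, (4-(tert-butyl)phenyl in place of 3-fluorophenyl on a sulfur), with 4-(tert-butyl)phenyl in place of 3-fluorophenyl on a sulfur. The rest of compound 1 is kept.

Among the compounds with values here, no two measured compounds differ in one place only, so the data give no size for this exchange, or for any other single change. The high number of compound 3 therefore cannot be carried over to this step. The nearest guide is the parent, compound 1 (8.56%). In this assay a step within the scatter is expected, with no firm direction, and the estimated step of a number 5.4 percentage points higher from compound 1 to compound 4 (within the scatter) is small. The estimated value for compound 4 is 14% (range 2% to 35%).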

Compound 4, percent growth inhibition at one concentration: 18.3%
The estimate for compound 4 lay 4.3 percentage points below the measured number, within the range that was stated.
By their numbers in this assay, from the lowest: compounds 1, 4 and 2 (each within the scatter of the next); then compound 3.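

In this assay, the exchange gives the first measured size for a single change in this series: 4-(tert-butyl)phenyl, with 10 heavy atoms, replaces 3-fluorophenyl, with 7, on a sulfur, and the result is a number 9.7 percentage points higher from compound 1 to compound 4 (within the scatter), a step that does not separate the two compounds. At this position on the core of compound 1, then, the loss of the fluorine together with the gain of the tert-butyl group leaves the number indistinguishable from that of the parent, and both groups are carbon-only six-membered aromatic rings with no hydrogen-bond donors or acceptors. Nothing measured here offers a reason for this outcome.

Going by these compounds, what a group of another kind would do on this sulfur remains open, for instance a phenyl ring carrying a carboxylic acid or a dimethylamino group, or a longer chain in place of the ring. On these data alone, it is also open whether 4-(tert-butyl)phenyl would give a similar result on the core of compound 2, and no single change yet accounts for the high number of compound 3.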